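A few compounds are considered here, and "the series" means these few. Any claim that something is new, unique, unknown or untested is made for them only; others in the source may bear on it.

The series shares one core, carried in compound 1 `CCOC(=O)c1c(-c2cccc(F)c2)[nH]c2cc(OC)ccc2c1=O`, compound 2 `CCOC(=O)c1c(-c2cccs2)[nH]c2cc(OC)ccc2c1=O` and compound 3 `CCOC(=O)c1c(-c2ccccc2C)[nH]c2cc(OC)ccc2c1=O`; the three differ only in the group attached on one aromatic carbon. In a physicochemical assay for solubility, in phosphate buffer, at pH 7.4 (a higher number here means a more soluble compound, a lower number a less soluble compound), compound 1 gives > 100000 nM, which is a limit of the assay rather than a number. In this assay compound 2 gives > 100000 nM, again a limit. In this assay compound 3 gives > 100000 nM, also a limit. All three values sit at the limit of > 100000 nM in this assay, at which 3 of the 3 values shown sit, so compound 3 stands level with the other two at that limit and no order among them can be read. The steps a step that the two limits leave unreadable from compound 1 to compound 2, a step that the two limits leave unreadable from compound 1 to compound 3 and a step that the two limits leave unreadable from compound 2 to compound 3 are therefore of unreadable size. Compound 4 `CCOC(=O)c1c(-c2ccc(OC)cc2)[nH]c2cc(OC)ccc2c1=O` differs from compound 3 by 4-methoxyphenyl in place of 2-methylphenyl on an aromatic carbon. The measured steps bear on this change only in that every compound stays at the limit (the limit of > 100000 nM in this assay, at which 3 of the 3 values shown sit), so no step beyond the scatter in this assay can be read in either direction. Compound 4 is expected to sit at the limit as well, with a step that the limit leaves unreadable from compound 3 to compound 4 expected to be nothing beyond the scatter. The estimate for compound 4 is 150000 nM, in the range 60000 nM to 400000 nM.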

Compound 4, solubility: 8000 nM
Beside the measured number, compound 4's estimate is 19-fold (1.27 log units) above it; measured number below the stated range.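

In this assay, the group on this aromatic carbon, ortho to the ethoxycarbonyl group, can clearly shift the read-out: 4-methoxyphenyl in place of 2-methylphenyl gives an at least 12-fold lower number from compound 3 to compound 4 (1.09 log units; beyond the scatter). The same group gives an at least 12-fold lower number from compound 2 to compound 4 (1.09 log units; beyond the scatter) in place of thiophen-2-yl and an at least 12-fold lower number from compound 1 to compound 4 (1.09 log units; beyond the scatter) in place of 3-fluorophenyl, so it stands apart from all three earlier groups. The steps among compound 1, compound 2 and compound 3 cannot be read, because all three sit at a limit: the limit of > 100000 nM in this assay, at which 3 of the 4 values shown sit.

As far as these compounds go, the full size of the three new steps stays open, as does whether the methoxy group itself accounts for them, which 4-methylphenyl or 3-methoxyphenyl could test. Also open, from the compounds shown here alone, is how a phenyl ring carrying an amine or a carboxylic acid would read in this assay.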